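Aminoquinoline ethers at the melanin-concentrating hormone receptor

This account rests on a few compounds, and the source may have more. Where it says the series, first, only, none or still open, it means among the compounds named here.

Measured so far:
compound 1 `Nc1ccc2cccc(OC3CCCCCC3)c2n1` — 137 nM
compound 2 `CCOCC(C)Oc1cccc2ccc(N)nc12` — 1070 nM
compound 3 `CCCCCOc1cccc2ccc(N)nc12` — 580 nM

In an assay on cells with melanin-concentrating hormone receptor 1 (Homo sapiens) as the target, read by radioligand binding (on this read-out lower numbers stand for stronger inhibition and higher numbers for weaker inhibition), compound 2 stands at the highest number of the three. Its nearest neighbour is compound 3, whose number lies within the scatter of it; the furthest is compound 1, whose number lies beyond the scatter.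

Compound 4 `CCC#CCOc1cccc2ccc(N)nc12` is not yet measured. Against compound 2 the change is a group of 5 heavy atoms (5 carbon; no ring) in place of a group of 6 heavy atoms (5 carbon, 1 oxygen; no ring), on an oxygen on an aromatic ring. Within the data shown here, one measured step bears on it: a 1.8-fold lower number from compound 2 to compound 3 (0.27 log units; within the scatter), where likewise a group of 5 heavy atoms (5 carbon; no ring) replaced the group of 6 heavy atoms on the same oxygen on an aromatic ring. Compound 4 keeps the chain length of compound 3 and adds a triple bond, for which nothing is measured. The expectation is therefore a small step down of the order of that step, within the scatter, as a 1.8-fold lower number from compound 2 to compound 4 (0.25 log units; within the scatter).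

Compound 4 is expected at 600 nM, with a range from 250 nM to 1500 nM.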

Compound 4, half-maximal inhibitory concentration: > 2000 nM
Compound 4: a limit, no number; the forecaster's own chance of this, stated with the estimate: 5%; at least 3.3-fold (0.52 log units) between middle value and limit.
By their numbers in this assay, from the lowest: compound 1; then compounds 3 and 2 (each within the scatter of the next). At a limit, above all of these: compound 4.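

In this assay compound 4 gives > 2000 nM, which is a limit of the assay and not a number. On this oxygen on an aromatic ring, the count of chain atoms does not settle the read-out: but-1-yn-1-yl in place of butyl on the saturated chain carbon gives an at least 3.4-fold higher number from compound 3 to compound 4 (0.53 log units; beyond the scatter), so a triple bond in the chain is not a neutral change here. The other step is a floor only, an at least 1.8-fold higher number from compound 2 to compound 4 (0.27 log units; that floor lies within the scatter), and that floor by itself does not separate the two compounds beyond the scatter.

From the compounds shown here alone, how far compound 4 lies past its limit stays open: the limit of > 2000 nM in this assay, at which 1 of the 4 values shown sits. Also open, going by these compounds, is whether an alkene at the same place in the chain, or a longer chain on this oxygen, reads like compound 3 or like compound 4.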